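Chloro for Isopropyl on a Non-Cytotoxic Core

The source may hold more compounds than are shown below. What is called first, only, known or untested is meant among the compounds shown, and "the series" means these compounds.

Compound 1 `CC(C)c1ccc(C(Nc2ccc(C3(C)NC(=O)c4ccccc4N3)cc2)c2nnnn2C2CCCCC2)cc1`: in an ADME assay on Vero cells (Chlorocebus sabaeus) for cytotoxicity, read by MTT assay, with a stated time of 72 h (a higher number here means that more compound is tolerated, a lower number that less compound is tolerated), compound 1 gives > 400000 nM, a limit of the assay rather than a number.
Compound 2 `CC(C)c1ccc(C(Nc2ccc(C3(C)NC(=O)c4ccccc4N3)cc2)c2nnnn2C(C)(C)C)cc1`: in this assay compound 2 gives > 400000 nM, again a limit.
Compound 3 `CC1(c2ccc(Nc3nc(NCc4ccco4)nc(NCc4ccco4)n3)cc2)NC(=O)c2ccccc2N1`: in this assay compound 3 gives "not determined" (no result reported).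

Compound 1 therefore sits at the top end of what this assay can report, shared with compound 2 (the limit of > 400000 nM in this assay, at which 2 of the 3 values shown sit). Among the measured compounds shown here, the single measured step, a step that the two limits leave unreadable from compound 1 to compound 2, cannot be sized because both of its ends are limits, so it gives no guide beyond showing that the core tolerates that swap. Compound 4 `CC1(c2ccc(NC(c3ccc(Cl)cc3)c3nnnn3C3CCCCC3)cc2)NC(=O)c2ccccc2N1` differs from compound 1 by chloro in place of isopropyl on an aromatic carbon. For the measured compounds named here, no measured step covers this change, and nothing among the values points away from the limit. The step that the limit leaves unreadable from compound 1 to compound 4 is expected to be none beyond the scatter. For compound 4 a value of 450000 nM is estimated, between 200000 nM and 1000000 nM.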

Compound 4, half-maximal cytotoxic concentration: > 400000 nM
Compound 4 ended at the assay's limit; the forecaster's own chance of this, stated with the estimate: 80%; the middle value lies beyond the limit too.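

Compound 1 and compound 4 both end at a limit of this assay rather than at a number, so no step between them can be read: the limit of > 400000 nM in this assay, at which 3 of the 4 values shown sit.

The compounds shown leave open whether chloro in place of isopropyl changes how well the cells tolerate the compound at all.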